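Trimethoxyphenyl for phenyl on a dienone-coumarin conjugate

A few compounds are considered here, and "the series" means these few. Any claim that something is new, unique, unknown or untested is made for them only; others in the source may bear on it.

Compound 1 `COc1cc(/C=C/C(=O)/C=C/c2ccccc2)ccc1OCc1cn(CCCOc2cc(=O)oc3ccccc23)nn1` stands highest of the two numbers in a functional assay on THP-1 cells (Homo sapiens) for inhibition, read by sulforhodamine B assay, with a stated time of 48 h, tested at 50 uM (a lower number here means less inhibition of growth, a higher number more inhibition of growth at the concentration tested), where compound 1 gives 48%. The nearest is compound 2 `COc1ccc(/C=C/C(=O)/C=C/c2ccc(OCc3cn(CCCCCOc4cc(=O)oc5ccccc45)nn3)c(OC)c2)cc1`, which in this assay gives 39%, within the scatter of compound 1. Compound 3 `COc1cc(/C=C/C(=O)/C=C/c2cc(OC)c(OC)c(OC)c2)ccc1OCc1cn(CCCOc2cc(=O)oc3ccccc23)nn1` carries the change 3,4,5-trimethoxyphenyl in place of phenyl on a double-bonded chain carbon bound to a double-bonded chain carbon relative to compound 1. For the measured compounds named here, no single-point step among the measured pair is available, so no size for this change is known from the series. The step from compound 1 to compound 3 is estimated as a number 4 percentage points higher from compound 1 to compound 3 (within the scatter), expected to be small and within the scatter. Compound 3 is expected to give 52% in this assay, with a range from 35% to 70%.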

Compound 3, percent growth inhibition at one concentration: 79%
Compound 3: middle estimate off by 27 percentage points, on the low side; measured number outside the range, above it.
By their numbers in this assay, from the lowest: compounds 2 and 1 (each within the scatter of the next); then compound 3.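

Under this assay the position on a double-bonded chain carbon bound to a double-bonded chain carbon proves sensitive: 3,4,5-trimethoxyphenyl in place of phenyl gives a number 31 percentage points higher from compound 1 to compound 3 (beyond the scatter) as the first single-place step in the series. The earlier pair differs in more than one place and gave no size for any change. No measurement at hand bears on the cause of this step.

Open, from the compounds shown here alone, is whether the same change holds on the chain of compound 2. Also open, going by these compounds, is how a phenyl carrying a dimethylamino group or a carboxylic acid would compare with the 3,4,5-trimethoxyphenyl of compound 3.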